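Cytotoxicity notes: 3-cyanobenzyl to 4-bromobenzyl

The source may report more compounds than this note shows. Statements on the series, on what has been measured and on what is new or still open speak of the compounds shown alone.

In a functional assay on MT4 cells (Homo sapiens) for cytotoxicity, read by MTT assay (on this read-out higher numbers stand for lower toxicity in this test and lower numbers for higher toxicity in this test), compound 1 (`Cc1c(O)nc(SCc2ccc(Cl)cc2)nc1Cc1c(Cl)cccc1Cl`) gives > 59000 nM, which is a limit. Compound 2 (`Cc1c(O)nc(SCc2cccc(C#N)c2)nc1Cc1c(Cl)cccc1Cl`) gives > 60000 nM, also a limit, so it has no exact position. For the measured compounds named here, the one measured step is a step that the two limits leave unreadable from compound 1 to compound 2. Compound 3 (`Cc1c(O)nc(SCc2ccc(Br)cc2)nc1Cc1c(Cl)cccc1Cl`) has 4-bromophenyl in place of 3-cyanophenyl on a saturated chain carbon bound to a sulfur. Its closest measured relative is compound 1, with 4-chlorophenyl, at > 59000 nM, again a limit. No step beyond the scatter is therefore expected in this assay, and the estimated step is an at least 1.1-fold lower number from compound 2 to compound 3 (0.05 log units; that floor lies within the scatter). Compound 3 is expected at 53000 nM, within an estimated range of 25000 nM to 70000 nM.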

Compound 3, half-maximal cytotoxic concentration: 13000 nM
The estimate for compound 3 lay 4.1-fold (0.61 log units) above the measured number; measured number outside the range, below it.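

For the compounds shown here, compound 3 gives the first exact number in this assay, so the group on a saturated chain carbon bound to a sulfur now shows a readable effect on this read-out, with an at least 4.6-fold lower number from compound 2 to compound 3 (0.66 log units; beyond the scatter). Bromo in place of chloro on an aromatic carbon is enough for an at least 4.5-fold lower number from compound 1 to compound 3 (0.65 log units; beyond the scatter), while the step between compound 1 and compound 2 cannot be read. Nothing at hand gives a cause for this drop.

Going by these compounds, both readable steps are floors, so the true distance from compound 3 stays open. Also open, on these data alone, is whether 4-iodophenyl or 4-aminophenyl in the same place would give a lower number still.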